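This account rests on a few compounds, and the source may have more. Where it says the series, first, only, none or still open, it means among the compounds named here.

Three close relatives built on one shared core have been tested for how strongly they switch on a receptor in a functional assay on HEK293 cells for agonist activity at Bombesin receptor subtype-3 (Homo sapiens), read by luminescence and calcium flux, with a stated time of 10 min; on this read-out lower numbers stand for an effect already at smaller amounts and higher numbers for an effect only at larger amounts of compound. Compound 1 `CCC(C)(C)Cc1c[nH]c(CCc2ccc(-c3cccc(N)n3)cc2)n1` gives 97 nM and stands second highest of the three numbers, yet both other compounds sit within the usual scatter of it. Compound 2 `CCC(C)(C)Cc1c[nH]c(CCc2ccc(-c3cccnc3)cc2)n1` gives 98 nM, and compound 3 `CCC(C)(C)Cc1c[nH]c(CCc2ccc(-c3cccc(C#N)n3)cc2)n1` gives 95 nM. The steps between the three are essentially flat: a 1.0-fold higher number from compound 1 to compound 2 (0.00 log units; within the scatter), a 1.0-fold lower number from compound 1 to compound 3 (0.01 log units; within the scatter) and a 1.0-fold lower number from compound 2 to compound 3 (0.01 log units; within the scatter). Exchanging one small aromatic ring for another on the aromatic carbon of the core has so far left the read-out untouched.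

Compound 4 `CCC(C)(C)Cc1c[nH]c(CCc2ccc(-c3ccc(F)cn3)cc2)n1` has not yet been measured. It differs from compound 1 at that same aromatic carbon: 5-fluoropyridin-2-yl in place of 6-aminopyridin-2-yl on an aromatic carbon. All three measured steps concern exchanges of exactly this kind of ring at exactly this place, and none of them moved the number beyond the scatter. The expectation for the step of no change at the digits printed from compound 1 to compound 4 (within the scatter) is therefore no change beyond the scatter in this assay. Compound 4 is accordingly estimated at 97 nM, with a likely range from 50 nM to 190 nM.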

Compound 4, half-maximal effective concentration: 97 nM
Estimate against measurement, compound 4: no gap at the digits printed; measured number inside the range.
By their numbers in this assay, from the lowest: compounds 3, 1, 4 and 2 (each within the scatter of the next).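

The new compound extends the flat picture to a group carrying fluorine: in this assay, 5-fluoropyridin-2-yl gives no change at the digits printed from compound 1 to compound 4 (within the scatter), a 1.0-fold higher number from compound 3 to compound 4 (0.01 log units; within the scatter) and a 1.0-fold lower number from compound 2 to compound 4 (0.00 log units; within the scatter). The step from compound 1 to compound 4 also replaces a group with 1 hydrogen-bond donor and 2 hydrogen-bond acceptors by one with 0 hydrogen-bond donors and 1 hydrogen-bond acceptor, and the number stays within the scatter, so at this position these counts show no link to the read-out across this one step. No supporting data are available to say why the read-out stays flat across these exchanges.

On these data alone, all four compounds carry a six-membered aromatic ring with 1 hetero atom at this place, so it remains open whether the flat picture would hold for a plain phenyl ring, a saturated ring such as morpholine, or a ring bearing a carboxylic acid. The compounds also leave open how the read-out responds to changes elsewhere on the shared core, since every step shown falls at this one place.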